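This account rests on a few compounds, and the source may have more. Where it says the series, first, only, none or still open, it means among the compounds named here.

Measured compounds:
compound 1 `NC(=O)c1c(NC(=O)c2ccccc2Cl)sc2c1CCN(Cc1ccc(Cl)cc1)C2` — > 50000 nM
compound 2 `Cc1ccc(C(=O)Nc2sc3c(c2C(N)=O)CCN(Cc2c(Cl)cccc2Cl)C3)cc1` — 47400 nM
compound 3 `NC(=O)c1c(NC(=O)c2ccccc2F)sc2c1CCN(Cc1cccc(Cl)c1)C2` — 49500 nM

Of the compounds shown here, three have been measured in a functional assay on HeLa cells (Homo sapiens) for antiproliferative activity, with a stated time of 24 h; on this read-out higher numbers stand for weaker inhibition and lower numbers for stronger inhibition. For compound 1 the value > 50000 nM is a limit of the assay and not a number; (the limit of > 50000 nM in this assay, at which 1 of the 3 values shown sits). Compound 2 gives 47400 nM and compound 3 gives 49500 nM; these two values lie within the scatter of each other. Compound 1 stands at a limit of the assay, so no order among the three can be drawn. Compound 4 `COc1ccccc1NC(=S)N1CCc2c(sc(NC(=O)c3ccccc3Cl)c2C(N)=O)C1` is not yet measured. It differs from compound 1 in one place: a group of 11 heavy atoms (8 carbon, 1 nitrogen, 1 oxygen, 1 sulfur; one six-membered aromatic ring of carbon only) in place of a group of 8 heavy atoms (7 carbon, 1 chlorine; one six-membered aromatic ring of carbon only), on an amine nitrogen in a ring. Among the compounds with values here, no step between measured compounds is available, so the size of the change from compound 1 cannot be read from the series. A step of no more than the scatter is expected, an at least 1.1-fold lower number from compound 1 to compound 4 (0.04 log units; that floor lies within the scatter). For compound 4 the estimate in this assay is 45000 nM, between 15000 nM and 120000 nM, with a real chance that only a limit is reported.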

Compound 4, half-maximal inhibitory concentration: > 50000 nM
Compound 4: no number, only a limit; the forecaster's own chance of this, stated with the estimate: 50%; middle value at least 1.1-fold (0.04 log units) away from the limit.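

In this assay compound 4 gives > 50000 nM, a limit and not a number. Within the data shown here, compound 1 also stands at a limit, so no step between compound 1 and compound 4 can be read. On these data alone, whether replacing 4-chlorobenzyl on the amine nitrogen in a ring changes antiproliferative activity at all stays open.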